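Benzylamino for 4-chlorophenyl on the carbonyl carbon

The source may report more compounds than this note shows. Statements on the series, on what has been measured and on what is new or still open speak of the compounds shown alone.

The series shares a core that compound 1 `O=C(Nc1ccccc1Cl)Nc1nn(-c2ccccc2)c(=O)c2ccccc12` displays, with the variation sitting on a carbonyl carbon whose other neighbour is an amide-type nitrogen. In an assay on CHO cells for displacement of a labelled ligand from adenosine receptor A1 (Homo sapiens), tested at 10 uM (on this read-out higher numbers stand for more inhibition at the one concentration tested (going by the name of the read-out) and lower numbers for less inhibition), compound 1 gives 0%. Compound 2 `O=C(Nc1nn(-c2ccccc2)c(=O)c2ccccc12)c1ccc(Cl)cc1` carries 4-chlorophenyl in that position and in this assay gives 26%. Within the data shown here, the only measured step, a number 26 percentage points higher from compound 1 to compound 2 (beyond the scatter), is the one that carries compound 2 to the highest of the two numbers seen so far, with compound 1 as its nearest and only neighbour.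

Compound 3 `O=C(NCc1ccccc1)Nc1nn(-c2ccccc2)c(=O)c2ccccc12` is now to be measured in this assay. Its difference from compound 2 is benzylamino in place of 4-chlorophenyl on a carbonyl carbon. The step from compound 1 to compound 2 is the only one that touches this position, and it shows that exchanging an arylamino for an aryl group directly on the carbonyl raised the number by a modest margin. Compound 3 returns to an amino substituent on the carbonyl, though with a benzyl rather than an aryl on its nitrogen, so compound 3 is expected to move back toward compound 1, a step of about a number 18 percentage points lower from compound 2 to compound 3 (beyond the scatter). For compound 3 the estimated value in this assay is therefore 8%, expected to fall between 0% and 22%.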

Compound 3, a percentage reported as inhibition, at one concentration (the size of the read-out at that concentration, not a potency): 20%
Beside the measured number, compound 3's estimate is 12 percentage points below it, and the stated range covers the measured number.
By their numbers in this assay, from the lowest: compound 1; then compounds 3 and 2 (each within the scatter of the next).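

In this assay, the step of a number 6 percentage points lower from compound 2 to compound 3 (within the scatter) leaves benzylamino and 4-chlorophenyl on the carbonyl carbon indistinguishable, so an amino nitrogen on this carbonyl does not by itself bring the number back to the level of the arylamino starting point. The step of a number 20 percentage points higher from compound 1 to compound 3 (beyond the scatter), with benzyl in place of 2-chlorophenyl on the amide-type nitrogen, shows that the group on that nitrogen, and not only the presence of the nitrogen, matters at this position. No measurement on hand accounts for these differences.

Open, going by these compounds, is whether phenylamino without chlorine, or a longer chain such as phenethylamino, on the carbonyl would keep the number seen with benzylamino or fall toward the number seen with 2-chlorophenylamino, which would show whether the chlorine or the aryl attachment goes with the low value. Also open, on these data alone, is whether an amine or a carboxylic acid on the benzyl ring would shift the number, and whether these single-concentration readings would correspond to any measurable potency.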